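A few compounds are considered here, and "the series" means these few. Any claim that something is new, unique, unknown or untested is made for them only; others in the source may bear on it.

Compound 3 `CC/C=C\C(=O)Nc1cc(Nc2nccc(-c3cn(C)c4ccc(F)cc34)n2)c(OC)cc1N(C)CCN(C)C` gives 3600 nM in a functional assay on A549 cells (Homo sapiens) for antiproliferative activity, read by MTT assay, with a stated time of 72 h (a higher number here means a weaker inhibitor, a lower number a stronger inhibitor), the highest of the three numbers in hand; compound 1 `COc1cc(N(C)CCN(C)C)c(NC(=O)/C=C\C(C)C)cc1Nc1nccc(-c2cn(C)c3ccccc23)n1`, which carries the branched chain without the fluorine, gives 612 nM, and compound 2 `C=CC(=O)Nc1cc(Nc2nccc(-c3cn(C)c4ccc(F)cc34)n2)c(OC)cc1N(C)CCN(C)C` gives 329 nM. The change to compound 4 `COc1cc(N(C)CCN(C)C)c(NC(=O)/C=C\C(C)C)cc1Nc1nccc(-c2cn(C)c3ccc(F)cc23)n1` is methyl in place of hydrogen on a saturated chain carbon bound to a double-bonded chain carbon and a saturated chain carbon. Within the data shown here, the only measured step on this chain, an 11-fold higher number from compound 2 to compound 3 (1.04 log units; beyond the scatter), concerns lengthening rather than branching and is large. Among the measured compounds shown here, no step on branching alone is measured; compound 1 carries the same 3-methylbut-1-en-1-yl group and sits at 612 nM, under compound 3. A lower number is therefore expected for compound 4 in this assay, a step of about a 4.5-fold lower number from compound 3 to compound 4 (0.65 log units; beyond the scatter). Compound 4 is estimated at 800 nM, within 300 nM to 2500 nM.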

Compound 4, half-maximal inhibitory concentration: 6140 nM
Compound 4: middle estimate off by 7.7-fold (0.89 log units), on the low side; measured number outside the range, above it.
By their numbers in this assay, from the lowest: compounds 2 and 1 (each within the scatter of the next); then compounds 3 and 4 (each within the scatter of the next).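

In this assay, adding methyl at this saturated chain carbon does not separate the two compounds: a 1.7-fold higher number from compound 3 to compound 4 (0.23 log units; within the scatter). The step of a 19-fold higher number from compound 2 to compound 4 (1.27 log units; beyond the scatter) shows that the large change seen on leaving vinyl also holds for 3-methylbut-1-en-1-yl, not only for but-1-en-1-yl. With that branched chain in place, the fluoro change is itself measurable: a 10-fold higher number from compound 1 to compound 4 (1.00 log units; beyond the scatter).

No measurement in hand accounts for these steps. Open, on these data alone, is how a longer chain or an amine on this carbonyl carbon would read, and whether the fluoro step holds with vinyl.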